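Propanoylamino for fluoro: tolerance in Vero cells

This account rests on a few compounds, and the source may have more. Where it says the series, first, only, none or still open, it means among the compounds named here.

The series shares one core, shown here as compound 1 `Fc1ccc(-c2nc3cc(C(F)(F)F)ccc3[nH]2)cc1`, and was examined in an ADME assay on Vero cells (Chlorocebus sabaeus) for cytotoxicity; a lower number here means that less compound is tolerated, a higher number that more compound is tolerated. Compound 1 gives 60000 nM in this assay. Among the two numbers recorded, compound 1 stands highest; its nearest neighbour is compound 2 `COc1ccc(-c2nc3cc(C(F)(F)F)ccc3[nH]2)c(N)c1`, which gives 50000 nM, a difference that lies within the scatter of repeated measurements. Compound 3 `COc1cc(OC)cc(-c2nc3cc(C(F)(F)F)ccc3[nH]2)c1` reached only a limit of the assay, > 100000 nM. That limit, (the limit of > 100000 nM in this assay, at which 1 of the 3 values shown sits), marks the ceiling at which the assay stops reporting a number.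

Compound 4 `CCC(=O)Nc1ccc(-c2nc3cc(C(F)(F)F)ccc3[nH]2)cc1` has not yet been measured in this assay. It differs from compound 1 by propanoylamino in place of fluoro on an aromatic carbon. Among the compounds with values here, no step between two measured compounds that differ in a single place is available here, so the direction of this change cannot be read from the measured pairs.

The two numbers and the one limit all sit in the same high region, and the new group is expected to leave compound 4 there as well. Compound 4 is estimated at 80000 nM, with a range from 30000 nM to 200000 nM. That estimate means a step from compound 1 to compound 4 of a 1.3-fold higher number from compound 1 to compound 4 (0.12 log units; within the scatter), which is expected to stay within the scatter, with a fair chance that only a limit is reported.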

Compound 4, half-maximal cytotoxic concentration: > 100000 nM
Compound 4 gave a limit, no number; the forecaster's own chance of this, stated with the estimate: 40%; middle value at least 1.2-fold (0.09 log units) from the limit.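

With an at least 1.6-fold higher number from compound 1 to compound 4 (0.22 log units; that floor lies within the scatter), the series gains its first step between two compounds that differ in a single place, and in this assay it shows that fluoro on this aromatic carbon, para to a large group, can give way to propanoylamino with no loss of tolerance. The exchange replaces a single fluorine with a group of five heavy atoms that brings one hydrogen-bond donor and one hydrogen-bond acceptor, so this position accepts a much larger substituent in this assay, although the floor of the step lies within the scatter and does not by itself establish a real gain. For compound 4 the reading is a limit and not a number, which leaves the true size of the step unknown: the limit of > 100000 nM in this assay, at which 2 of the 4 values shown sit.

From the compounds shown here alone, how far tolerance of compound 4 extends past that limit remains open, as does whether the gain is real. Going by these compounds, it is also open whether an amine, a carboxylic acid or a longer acyl chain on this same aromatic carbon would stay at the limit or bring the number down.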